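The source may hold more compounds than are shown below. What is called first, only, known or untested is meant among the compounds shown, and "the series" means these compounds.

In a functional assay on MT4 cells (Homo sapiens) for cytotoxicity (on this read-out lower numbers stand for stronger inhibition and higher numbers for weaker inhibition), no exact number exists yet for any measured compound. Compound 1 `COc1cccc([S+]([O-])c2cccc(N)c2C#N)c1` gives > 80000 nM and this is a limit of the assay. Compound 2 `N#Cc1c(N)cccc1S(=O)(=O)c1ccccc1` gives > 5000 nM and this is likewise a limit. Compound 3 `Cc1ccccc1S(=O)(=O)c1cccc(N)c1C#N` gives > 200000 nM and this too is only a limit. Compound 4 `N#Cc1ccccc1S(=O)(=O)c1cccc(N)c1C#N` differs from compound 3 by cyano in place of methyl on an aromatic carbon with cyano in place of methyl on an aromatic carbon. Going by the values given here, the only measured step that bears on this change is a step that the two limits leave unreadable from compound 2 to compound 3 and its size cannot be read. With no measured size to build on, the estimated at least 1.3-fold lower number from compound 3 to compound 4 (0.12 log units; that floor lies within the scatter) in this assay has no direction and stays within the usual scatter. Compound 4 is expected at about 150000 nM with an estimated range from 40000 nM to 350000 nM in this assay.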

Compound 4, half-maximal inhibitory concentration: > 200000 nM
Compound 4 gave a limit, no number; the forecaster's own chance of this, stated with the estimate: 80%; middle value at least 1.3-fold (0.12 log units) from the limit.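

In this assay compound 4 gives only a limit, so the steps to it from compound 2 and from compound 3 cannot be read. The compounds shown leave open whether cyano in place of methyl on an aromatic carbon changes the read-out at all.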